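The source may report more compounds than this note shows. Statements on the series, on what has been measured and on what is new or still open speak of the compounds shown alone.

Measured compounds in an ADME assay on HEK293 cells (Homo sapiens) for cytotoxicity, with a stated time of 72 h; on this read-out higher numbers stand for an effect only at larger amounts of compound and lower numbers for an effect already at smaller amounts:

Compound 1 `O=C(Nc1ccc(O)c(-c2nc3ccccc3s2)c1)c1cc([N+](=O)[O-])ccc1Cl` gives > 25000 nM, a limit of this assay and not a number.
Compound 2 `Cc1cc(NC(=O)c2cc([N+](=O)[O-])ccc2Cl)cc(-c2nc3ccccc3s2)c1O` gives > 25000 nM, again a limit.
Compound 3 `O=C(Nc1cccc(-c2nc3ccccc3s2)c1)c1cc([N+](=O)[O-])ccc1Cl` gives > 27000 nM, also a limit.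

Notes. The step that the two limits leave unreadable from compound 1 to compound 2 goes with the change (methyl in place of hydrogen on an aromatic carbon). The step that the two limits leave unreadable from compound 1 to compound 3 goes with the change (hydrogen in place of hydroxy on an aromatic carbon), which is also how the core of compound 1 differs from the core of compound 3. Two of the three values sit at the limit of > 25000 nM in this assay, at which 2 of the 3 values shown sit, and one at the limit of > 27000 nM in this assay, at which 1 of the 3 values shown sits, so no ordering among compounds 1, 2 and 3 can be read from this assay.

Compound 4 `Cc1c(NC(=O)c2cc([N+](=O)[O-])ccc2Cl)cccc1-c1nc2ccccc2s1` is not yet measured in this assay. It differs from compound 3 by methyl in place of hydrogen on an aromatic carbon. This is the same kind of change as from compound 1 to compound 2, but not the same: there the methyl enters ortho to a hydroxy group and meta to the 1,3-benzothiazol-2-yl group, here it enters ortho to the 1,3-benzothiazol-2-yl group, ortho to a large group. Since the measured step from compound 1 to compound 2 is unreadable, the expected step that the limit leaves unreadable from compound 3 to compound 4 rests only on compound 3 standing at a limit > 27000 nM. Compound 4 is therefore expected to give about 30000 nM, with a range from 15000 nM to 80000 nM, most likely reported again as a limit.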

Compound 4, half-maximal effective concentration: > 25000 nM
Compound 4 ended at the assay's limit; the forecaster's own chance of this, stated with the estimate: 85%; the middle value does not contradict the limit.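

In this assay compound 4 gives > 25000 nM, a limit and not a number. For the compounds shown here, compound 3 also stands at a limit, and no step between compound 3 and compound 4 can be read. The compounds shown leave open at what concentration any of them has an effect, and whether methyl in place of hydrogen changes that concentration.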